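Adding a methyl group to compound 2

The compounds below may be only part of what the source reports. "The series", "measured", "known", "first", "only" and "open" are said of these compounds alone.

Compound 1 `S=C(N/N=C/c1cccs1)Nc1ccc(Cl)cc1`, compound 2 `S=C(N/N=C/c1cccs1)Nc1ccccc1` and compound 3 `S=C(N/N=C/c1cccs1)Nc1cccc2ccccc12` share one core and differ in a single aromatic group. In a functional assay on UACC-62 cells (Homo sapiens) for inhibition, read by sulforhodamine B assay, with a stated time of 48 h (a lower number here means a stronger inhibitor of growth, a higher number a weaker inhibitor of growth), compound 1 gives 15800 nM, a true measured number. Compound 2 reads > 100000 nM, which is a limit of the assay and not a number. Compound 3 reads > 100000 nM, which is also a limit. Compound 2 therefore stands at the limit of > 100000 nM in this assay, at which 2 of the 3 values shown sit, so its real position is not known.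

Compound 4 `Cc1ccc(NC(=S)N/N=C/c2cccs2)cc1` changes compound 2 in one place: methyl in place of hydrogen on an aromatic carbon. Going by the values given here, the only measured step that bears on this change is an at least 6.3-fold higher number from compound 1 to compound 2 (0.80 log units; beyond the scatter), where hydrogen takes the place of chloro on an aromatic carbon, para to a large group. That step, seen from compound 2, suggests that a group added at this carbon could bring a lower number in this assay. However, it rests on a single pair, methyl is not chloro, and compound 4 could well stay at the limit. The expected change is therefore a modest one towards stronger inhibition, and the estimated step is an at least 2.2-fold lower number from compound 2 to compound 4 (0.34 log units; beyond the scatter). The estimated value for compound 4 is 45000 nM, with an expected range from 10000 nM to 100000 nM.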

Compound 4, concentration for 50% growth inhibition: 16800 nM
Compound 4: middle estimate off by 2.7-fold (0.43 log units), on the high side, within the range that was stated.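

At this carbon, para to a large group, a second and quite different substituent now lowers the number: in this assay, the change from hydrogen to methyl gives an at least 5.9-fold lower number from compound 2 to compound 4 (0.77 log units; beyond the scatter), whereas earlier only chloro had been seen to do this. The two substituted compounds cannot be told apart, with a 1.1-fold higher number from compound 1 to compound 4 (0.03 log units; within the scatter), so in this assay methyl serves as well as chloro at this carbon, and the earlier effect is not unique to chloro. From the compounds shown here alone, the full size of the gain from hydrogen to methyl stays unknown, and the step gives only its lower bound, because compound 2 has no true number to start from: the limit of > 100000 nM in this assay, at which 2 of the 4 values shown sit.

Going by these compounds, two compounds with a substituent at this carbon are too few to show which features of a group matter, so it remains open whether a methoxy group, an amine, a carboxylic acid or a longer chain such as ethyl would match methyl and chloro or go clearly beyond them. On these data alone, it is also open whether methyl would have the same effect on a different carbon of this ring.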